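Methoxy for 4-fluorophenyl on a thiazolidinedione chromane

The source may hold more compounds than are shown below. What is called first, only, known or untested is meant among the compounds shown, and "the series" means these compounds.

Measured so far:
compound 1, `CC(C)=CCOc1c(C)c(C)c2c(c1C)CCC(C)(COc1ccc(/C=C3\SC(=O)NC3=O)cc1-c1ccc(F)cc1)O2`, 92%
compound 2, `Cc1c(C)c2c(c(C)c1OC(=O)CCC(=O)O)CCC(C)(COc1ccc(/C=C3\SC(=O)NC3=O)cc1)O2`, 98%

In a functional assay on MCF7 cells (Homo sapiens), tested at 5 uM (on this read-out lower numbers stand for a stronger effect and higher numbers for a weaker effect at the one concentration tested), compound 1 gives 92% and compound 2 gives 98%. Compound 1 has the lower of the two numbers, but the gap to compound 2 lies within the usual scatter of repeated measurements, so the two compounds cannot be told apart on this read-out; both leave the read-out close to the level of an untreated control.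

Compound 3, `COc1cc(/C=C2\SC(=O)NC2=O)ccc1OCC1(C)CCc2c(C)c(OCC=C(C)C)c(C)c(C)c2O1`, has not yet been measured in this assay. Its difference from compound 1 is a single change on the shared core: methoxy in place of 4-fluorophenyl on an aromatic carbon.

Among the measured compounds shown here, no step between two measured compounds is available to show what such a change does in this assay. With both measured numbers close together and close to a weak effect, the step from compound 1 to compound 3 is expected to be small, with no clear direction, and to stay within the scatter, giving a number 1 percentage points higher from compound 1 to compound 3 (within the scatter). Compound 3 is therefore estimated to give 93%, expected between 80% and 105%.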

Compound 3, a percentage reported as activity, at one concentration (the size of the read-out at that concentration, not a potency): 78%
Compound 3: the middle estimate sits 15 percentage points above what was measured; the measured number lies below the stated range.
By their numbers in this assay, from the lowest: compound 3; then compounds 1 and 2 (each within the scatter of the next).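

Among the compounds shown here, replacing 4-fluorophenyl with methoxy gives the only step in this set that can be read in this assay, a number 14 percentage points lower from compound 1 to compound 3 (beyond the scatter), and it lies beyond the scatter, so the group on this aromatic carbon, ortho to a large group, can change the read-out at the one concentration tested. The step is modest, and compound 3 carries a smaller group than compound 1: methoxy has 2 heavy atoms and no ring, while 4-fluorophenyl has 7 heavy atoms and one six-membered aromatic ring, and methoxy adds 1 hydrogen-bond acceptor where 4-fluorophenyl has none. Nothing measured here explains the step or shows which of these differences matters.

From the compounds shown here alone, whether the lower number follows from the loss of 4-fluorophenyl, the arrival of methoxy or both remains open, as a single pair cannot separate them. A hydroxyl group, an ethoxy chain or an amine on the same aromatic carbon of the shared core would show whether the effect depends on the oxygen, the length of the chain or neither.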